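The compounds below may be only part of what the source reports. "The series", "measured", "known", "first", "only" and "open" are said of these compounds alone.

In a functional assay on MIA PaCa-2 cells (Homo sapiens) for inhibition, read by MTT assay, with a stated time of 72 h, tested at 50 uM (on this read-out lower numbers stand for less inhibition of growth and higher numbers for more inhibition of growth at the one concentration tested), compound 1 (`C=CCc1cc(O)c(O)c(CN2CCC(C)CC2)c1`) gives 90.6% and compound 2 (`C=CCc1ccc(OCc2cn(-c3ccc(C#N)cc3)nn2)c(O)c1`) gives 45.9% as the lower of the two numbers, a gap beyond the usual scatter. Compound 3 (`C=CCc1ccc(OCc2cn(-c3ccccc3CO)nn2)c(O)c1`) has 2-(hydroxymethyl)phenyl in place of 4-cyanophenyl on an aromatic nitrogen and is otherwise the same as compound 2. Among the measured compounds shown here, no two measured compounds differ in only one place, so the data offer no direct guide to this swap. The expected change is a number 0.9 percentage points lower from compound 2 to compound 3 (within the scatter) and so no shift beyond the scatter. For compound 3 the estimate is 45% with 25% to 65% as its expected range.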

Compound 3, percent growth inhibition at one concentration: 52.1%
Estimate against measurement, compound 3: 7.1 percentage points below, within the range that was stated.
By their numbers in this assay, from the lowest: compounds 2 and 3 (each within the scatter of the next); then compound 1.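

In this assay, putting 2-(hydroxymethyl)phenyl in place of 4-cyanophenyl on the aromatic nitrogen gives a number 6.2 percentage points higher from compound 2 to compound 3 (within the scatter), a direct reading at this position that compound 1 could not give. The nitrile can thus leave and a hydroxymethyl group with its hydrogen-bond donor can enter without a shift beyond the scatter. Nothing available explains why these two groups read alike. Going by these compounds, since the group and its place on the phenyl ring change together, their separate contributions stay open. On these data alone, how an amine or a carboxylic acid on that ring would read also stays open.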